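A few compounds are considered here, and "the series" means these few. Any claim that something is new, unique, unknown or untested is made for them only; others in the source may bear on it.

Working notes on the shared core of compound 1 `COc1ccc(-c2cnc(NC(=O)c3ccccn3)n2C)cc1`, varied in the group on a carbonyl carbon. In a toxicity assay on THP-1 cells (Homo sapiens) for inhibition (a higher number here means that more compound is tolerated, a lower number that less compound is tolerated), compound 1 reaches only the limit > 100000 nM, not a number. Compound 2 `COc1ccc(-c2cnc(NC(=O)c3ccccc3)n2C)cc1` carries phenyl in place of pyridin-2-yl on a carbonyl carbon; in this assay compound 2 likewise stops at the limit > 100000 nM. Compound 3 `COc1ccc(-c2cnc(NC(=O)c3ccc(Cl)cc3)n2C)cc1` carries 4-chlorophenyl in place of pyridin-2-yl on a carbonyl carbon; in this assay compound 3 also gives only the limit > 100000 nM. Accordingly a step that the two limits leave unreadable from compound 1 to compound 2, a step that the two limits leave unreadable from compound 1 to compound 3 and a step that the two limits leave unreadable from compound 2 to compound 3 are all of unreadable size because of the limit of > 100000 nM in this assay, at which 3 of the 3 values shown sit. Compound 3 thus stands at the same limit as every other measured compound, with no number to place it on a scale.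

Compound 4 `COc1ccc(-c2cnc(NC(=O)c3ccncc3)n2C)cc1` differs from compound 3 by pyridin-4-yl in place of 4-chlorophenyl on a carbonyl carbon. The measured steps bearing on this change all exchange the group on a carbonyl carbon and none produced a readable shift, so no step beyond the scatter is expected in this assay. The step from compound 3 to compound 4 is expected to be a number no higher from compound 3 to compound 4 (the limit leaves the size open). Compound 4 is estimated at 100000 nM in this assay, with an expected range from 40000 nM to 300000 nM, most likely again reported only as a limit.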

Compound 4, half-maximal cytotoxic concentration: > 100000 nM
Compound 4 ended at the assay's limit (the forecaster's own chance of this, stated with the estimate: 85%); the middle value sits exactly at the limit.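

No step can be read between compound 4 and compounds 1, 2 or 3, because each result is a limit and not a number: the limit of > 100000 nM in this assay, at which 4 of the 4 values shown sit.

The compounds shown leave open whether any group on the carbonyl carbon of the shared core would give a readable number in this assay.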